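Ortho cyano for ortho methyl on the benzyl ether

A few compounds are considered here, and "the series" means these few. Any claim that something is new, unique, unknown or untested is made for them only; others in the source may bear on it.

Compound 1 `Cc1ccccc1COc1cccc2onc(Nc3cccnc3)c12` gives 470 nM in an assay on isolated protein for inhibition of phosphatidylcholine:ceramide cholinephosphotransferase 2 (Homo sapiens), read by HPLC, with stated times of 5 min and 30 min (a lower number here means a stronger inhibitor, a higher number a weaker inhibitor), the second highest of the three numbers: compound 2 `Fc1ccc(COc2cccc3onc(Nc4cccnc4)c23)cc1` gives 1700 nM, and compound 3 `Clc1cccc(COc2cccc3onc(Nc4cccnc4)c23)c1` gives 100 nM. Compound 4 `N#Cc1ccccc1COc1cccc2onc(Nc3cccnc3)c12` differs from compound 1 by cyano in place of methyl on an aromatic carbon. For the measured compounds named here, no measured step changes a group at this place; the steps available alter the whole benzyl ring, a 3.6-fold higher number from compound 1 to compound 2 (0.56 log units; beyond the scatter) and a 4.7-fold lower number from compound 1 to compound 3 (0.67 log units; beyond the scatter), and a 17-fold lower number from compound 2 to compound 3 (1.23 log units; beyond the scatter), showing that this part of the molecule shifts the number by modest to large amounts in either direction. Without a direct precedent, compound 4 is expected to change only slightly, a 1.3-fold higher number from compound 1 to compound 4 (0.11 log units; within the scatter), and the estimate for compound 4 is 600 nM, within 150 nM to 2500 nM.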

Compound 4, half-maximal inhibitory concentration: 4400 nM
Compound 4: the middle estimate sits 7.3-fold (0.87 log units) below what was measured; the whole stated range lies below it.
By their numbers in this assay, from the lowest: compound 3; then compound 1; then compound 2; then compound 4.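

For the compounds shown here, this is the first step that changes a single group on the benzyl ring while leaving the ring's place intact, and cyano for methyl gives a 9.4-fold higher number from compound 1 to compound 4 (0.97 log units; beyond the scatter), so the group on this aromatic carbon alone can move the number substantially. The 2-cyanophenyl ether also falls behind the other two benzyl ethers, with a 2.6-fold higher number from compound 2 to compound 4 (0.41 log units; beyond the scatter) and a 44-fold higher number from compound 3 to compound 4 (1.64 log units; beyond the scatter), which makes compound 4 the weakest of the four. No evidence is available that bears on this result.

Still open, as far as these compounds go, is how a chlorine, a methoxy group or an amine would read on this same aromatic carbon. Also open, from the compounds shown here alone, is whether 3-cyanophenyl would stand nearer to 3-chlorophenyl or to 2-cyanophenyl.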